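The compounds below may be only part of what the source reports. "The series", "measured", "known", "first", "only" and "open" are said of these compounds alone.

Measured in a functional assay on HCT-116 cells (Homo sapiens) for antiproliferative activity, read by sulforhodamine B assay, with a stated time of 72 h; a lower number here means a stronger inhibitor, a higher number a weaker inhibitor:
- compound 1 `COc1ccc(CNc2cnc3ccc(-c4cnc(OC)c(NS(=O)(=O)c5ccc(F)cc5F)c4)cc3c2OC)cc1`: 10200 nM
- compound 2 `COc1ncc(-c2ccc3ncc(NC(=O)CN4CCN(C)CC4)c(OC)c3c2)cc1NS(=O)(=O)c1ccc(F)cc1F`: 1540 nM
- compound 3 `COc1ncc(-c2ccc3ncc(NCC4CCN(S(C)(=O)=O)CC4)c(OC)c3c2)cc1NS(=O)(=O)c1ccc(F)cc1F`: 1360 nM

Compound 3 and compound 2 sit level at the low end of this small set, with a 1.1-fold lower number from compound 2 to compound 3 (0.05 log units; within the scatter). Compound 1 stands apart, as shown by a 6.6-fold lower number from compound 1 to compound 2 (0.82 log units; beyond the scatter) and by a 7.5-fold lower number from compound 1 to compound 3 (0.88 log units; beyond the scatter).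

Compound 4 `COc1ncc(-c2ccc3ncc(NC(C)=O)c(OC)c3c2)cc1NS(=O)(=O)c1ccc(F)cc1F` keeps the shared core and alters one group: acetyl in place of (1-(methylsulfonyl)piperidin-4-yl)methyl on a nitrogen on an aromatic ring. The closest evidence is compound 2, which also has a carbonyl on that nitrogen, and its step to compound 3 was a 1.1-fold lower number from compound 2 to compound 3 (0.05 log units; within the scatter). The modest steps from compound 1 show that the group on this nitrogen can shift the number, but they start from 4-methoxybenzyl, which compound 4 does not carry. Among the compounds with values here, no measured compound has so small a group there, so the direction stays open and no step beyond the scatter is expected. The expected change is a 1.0-fold lower number from compound 3 to compound 4 (0.02 log units; within the scatter). For compound 4 the estimated value is 1300 nM, with an expected range from 350 nM to 5000 nM.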

Compound 4, half-maximal inhibitory concentration: 550 nM
Estimate against measurement, compound 4: 2.4-fold (0.37 log units) above; measured number inside the range.
By their numbers in this assay, from the lowest: compound 4; then compounds 3 and 2 (each within the scatter of the next); then compound 1.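

In this assay, acetyl, the smallest group on this nitrogen among these compounds, gives the lowest number of the set, so shortening the group from (1-(methylsulfonyl)piperidin-4-yl)methyl does not leave the number unchanged (a 2.5-fold lower number from compound 3 to compound 4 (0.39 log units; beyond the scatter)). Among the compounds with a carbonyl on this nitrogen, hydrogen in place of 4-methylpiperazin-1-yl on the saturated chain carbon bound to a carbonyl carbon also lowers the number (a 2.8-fold lower number from compound 2 to compound 4 (0.45 log units; beyond the scatter)), and the step from 4-methoxybenzyl to acetyl is the largest here (a 19-fold lower number from compound 1 to compound 4 (1.27 log units; beyond the scatter)). Nothing shown gives a reason for these steps.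

As far as these compounds go, it remains open whether a free amine or a longer acyl chain such as propanoyl on this nitrogen would lower the number further. From the compounds shown here alone, it is also open whether the carbonyl matters, which a plain ethyl group there could test.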